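A few compounds are considered here, and "the series" means these few. Any claim that something is new, unique, unknown or untested is made for them only; others in the source may bear on it.

The measured compounds:
compound 1 `COc1cncc(C2=CC3CC(C2)CN(C)C3)c1`, 596 nM
compound 2 `Clc1ccc(Oc2cncc(C3=CC4CNCC(C3)C4)c2)cc1`, 40 nM
compound 3 `Clc1ccccc1Oc1cncc(C2=CC3CNCC(C2)C3)c1`, 26 nM

In an in vitro assay on SH-SY5Y cells for displacement of a labelled ligand from Neuronal acetylcholine receptor; alpha3/beta4 (Homo sapiens) (a higher number here means a weaker inhibitor, a lower number a stronger inhibitor), compound 3 gives the lowest of the three numbers. Its nearest neighbour is compound 2, which in this assay gives 40 nM; the step of a 1.5-fold lower number from compound 2 to compound 3 (0.19 log units; within the scatter) lies within the scatter, so the two cannot be ordered. The furthest of the three is compound 1; it differs in more than one place from the other two and gives 596 nM.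

Compound 4 `COc1ccc(Oc2cncc(C3=CC4CNCC(C3)C4)c2)cc1` is not yet measured. It differs from compound 3 by 4-methoxyphenyl in place of 2-chlorophenyl on an oxygen on an aromatic ring. Among the compounds with values here, the one measured step that bears on this site is a 1.5-fold lower number from compound 2 to compound 3 (0.19 log units; within the scatter), and it was within the scatter, so exchanging 4-chlorophenyl for 2-chlorophenyl changed little. Within the data shown here, no measured compound carries a methoxy group on that phenyl ring, so a methoxy in place of chlorine is not covered by the data. The expectation for compound 4 is therefore a step of about a 1.9-fold higher number from compound 3 to compound 4 (0.28 log units; within the scatter), not clearly beyond the scatter. Compound 4 is estimated at 50 nM, with a range from 20 nM to 130 nM.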

Compound 4, inhibition constant: 27 nM
Estimate against measurement, compound 4: 1.9-fold (0.27 log units) above; the measured number falls inside the stated range.
By their numbers in this assay, from the lowest: compounds 3, 4 and 2 (each within the scatter of the next); then compound 1.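

In this assay, methoxy in place of chloro on an aromatic carbon gives a 1.5-fold lower number from compound 2 to compound 4 (0.17 log units; within the scatter), and 4-methoxyphenyl in place of 2-chlorophenyl gives a 1.0-fold higher number from compound 3 to compound 4 (0.02 log units; within the scatter); both steps lie within the scatter. The earlier compounds had shown only that the two chlorophenyl groups could not be separated on this oxygen, whereas compound 4 shows that a phenyl group carrying methoxy rather than chlorine also cannot be separated from them. Nothing available explains why this exchange leaves the number within the scatter.

The compounds shown leave open whether an unsubstituted phenyl, a 2-methoxyphenyl or a phenyl carrying an amine or a carboxylic acid would stay as close. They also leave open how a longer chain in place of methoxy would read in this assay.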